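The compounds below may be only part of what the source reports. "The series", "measured", "known", "first", "only" and "open" are said of these compounds alone.

Three compounds have been measured in an assay on isolated protein for inhibition of protein deacetylase HDAC6 (Homo sapiens), with a stated time of 15 min, tested at 1 uM; on this read-out lower numbers stand for less inhibition and higher numbers for more inhibition at the one concentration tested (going by the name of the read-out):
compound 1, `CNC(=O)CCCCCCCn1nc(-c2ccc3oc(N)nc3c2)c2c(N)ncnc21`, gives 99.1%;
compound 2, `Nc1nc2cc(-c3nn(CCCCCC(=O)NO)c4ncnc(N)c34)ccc2o1`, gives 97.8%;
compound 3, `Nc1nc2cc(-c3nn(CCCCC(=O)NO)c4ncnc(N)c34)ccc2o1`, gives 95.1%.

Compound 3 holds the lowest of the three numbers, yet the step of a number 2.7 percentage points lower from compound 2 to compound 3 (within the scatter) and the step of a number 4 percentage points lower from compound 1 to compound 3 (within the scatter) both stay within the scatter, so in this assay the three compounds cannot be told apart; their numbers sit level, all high at the single concentration tested.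

Compound 4, `Nc1nc2cc(-c3nn(CCCCCCC(=O)NO)c4ncnc(N)c34)ccc2o1`, differs from compound 3 in one place: 2-(hydroxycarbamoyl)ethyl in place of hydroxycarbamoyl on a saturated chain carbon, four bonds along the chain from an aromatic nitrogen. The measured step that bears most directly on this change is a number 2.7 percentage points lower from compound 2 to compound 3 (within the scatter), which shortens the same chain by one carbon and stays within the scatter. The steps of a number 1.3 percentage points lower from compound 1 to compound 2 (within the scatter) and a number 4 percentage points lower from compound 1 to compound 3 (within the scatter) exchange a different chain end and likewise stay within the scatter. Within the data shown here, nothing among the measured compounds points to a step beyond the scatter when the chain between the aromatic nitrogen and the hydroxycarbamoyl group is lengthened by two carbons. Compound 4 is therefore expected to give 97% in this assay, with a range from 92% to 100%. The expected step of a number 1.9 percentage points higher from compound 3 to compound 4 (within the scatter) is estimated to remain within the scatter.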

Compound 4, a percentage reported as inhibition, at one concentration (the size of the read-out at that concentration, not a potency): 99%
For compound 4 the middle estimate is 2 percentage points below the measured one; the range from low to high includes it.
By their numbers in this assay, from the lowest: compounds 3, 2, 4 and 1 (each within the scatter of the next).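

With 2-(hydroxycarbamoyl)ethyl in place of hydroxycarbamoyl on a saturated chain carbon, four bonds along the chain from an aromatic nitrogen, the step of a number 3.9 percentage points higher from compound 3 to compound 4 (within the scatter) in this assay shows that this position carries the longer hydroxycarbamoyl chain of compound 4 with no step beyond the scatter, and the step of a number 1.2 percentage points higher from compound 2 to compound 4 (within the scatter) shows the same for the extension by (hydroxycarbamoyl)methyl. The step of a number 0.1 percentage points lower from compound 1 to compound 4 (within the scatter) adds that hydroxycarbamoyl in place of (methylcarbamoyl)methyl, six bonds along the chain from an aromatic nitrogen, also leaves the two compounds level, so across these four compounds neither this chain length nor this chain end separates the numbers at the one concentration tested. No accompanying evidence bears on why these numbers sit level.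

All four numbers lie high on the read-out at a single concentration, so any difference in potency among these compounds remains open. Also open, on these data alone, is what a carboxylic acid or an amine at the chain end, or a chain shorter than that of compound 3, would give at this position in this assay and whether the level numbers would persist.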